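The source may report more compounds than this note shows. Statements on the series, on what has been measured and on what is new or still open speak of the compounds shown alone.

Compound 1 `B[P@](=O)(OC[C@H]1O[C@@H](n2cc(OC)c(=O)[nH]c2=O)[C@H](O)[C@@H]1O)OP(=O)(O)OP(=O)(O)O` is a boranophosphate nucleotide, and in an in vitro functional assay on 1321-N1 cells for agonist activity at P2Y purinoceptor 6 (Homo sapiens), read by fluorescence, spectrophotometry and calcium flux (a lower number here means that less compound is needed, a higher number that more compound is needed for the effect), compound 1 gives 20100 nM. Compound 2 `COc1cn([C@@H]2O[C@H](COP(=O)(O)OP(=O)(O)OP(=O)(O)OC[C@H]3O[C@@H](n4cc(OC)c(=O)[nH]c4=O)[C@H](O)[C@@H]3O)[C@@H](O)[C@H]2O)c(=O)[nH]c1=O` is a dinucleoside triphosphate. In this assay compound 2 gives only the limit > 10000 nM and not a number, as recorded in the limit of > 10000 nM in this assay, at which 1 of the 2 values shown sits. Compound 3 `BP(=O)(OP(=O)(O)OC[C@H]1O[C@@H](n2cc(OC)c(=O)[nH]c2=O)[C@H](O)[C@@H]1O)OP(=O)(O)OC[C@H]1O[C@@H](n2cc(OC)c(=O)[nH]c2=O)[C@H](O)[C@@H]1O` differs from compound 2 by one boron atom in place of one oxygen atom, on a phosphorus. No measured step of this kind exists among these compounds, so the change is expected to fall a number no higher from compound 2 to compound 3 (the limit leaves the size open), a step within the usual scatter. Compound 3 is therefore estimated at 10000 nM, with a range from 2500 nM to 40000 nM.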

Compound 3, half-maximal effective concentration: 200 nM
Compound 3: the middle estimate sits 50-fold (1.70 log units) above what was measured; measured number below the stated range.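

In this assay, one boron atom in place of one oxygen atom, on a phosphorus, gives an at least 50-fold lower number from compound 2 to compound 3 (1.69 log units; beyond the scatter). Among the compounds shown here, this is the first measured sign that a single atom exchange at this phosphorus can move the number beyond the scatter, which neither earlier compound could show on its own. The full size of the step stays unknown, since compound 2 carries only a limit: the limit of > 10000 nM in this assay, at which 1 of the 3 values shown sits.

Going by these compounds, whether a sulfur atom or a methyl group on this phosphorus would move the number in the same way remains open.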